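Ester-to-acid step in a vitamin D receptor antagonist series

The source may report more compounds than this note shows. Statements on the series, on what has been measured and on what is new or still open speak of the compounds shown alone.

Measured so far:
compound 1, `COC(=O)c1ccccc1OCc1oc(-c2ccccc2OC)nc1C`, 20200 nM
compound 2, `COC(=O)c1ccccc1OCc1oc(-c2cccc(OC)c2)nc1C`, 15400 nM

Both numbers come from an assay on cells for antagonist activity at vitamin D3 receptor (Homo sapiens), read by a luciferase reporter; a lower number here means a stronger inhibitor, a higher number a weaker inhibitor. Among the compounds with values here, compound 1 gives the higher of the two values, but its only neighbour, compound 2, sits within the scatter: a 1.3-fold lower number from compound 1 to compound 2 (0.12 log units; within the scatter). Within the data shown here, the series therefore has no step yet that is larger than the noise.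

Compound 3, `COc1ccccc1-c1nc(C)c(COc2ccccc2C(=O)O)o1`, differs from compound 1 by hydrogen in place of methyl on an oxygen next to a carbonyl group; cut one bond further out, methoxycarbonyl becomes carboxy. Among the measured compounds shown here, no measured pair in this set changes that position; the single step on record, from compound 1 to compound 2, concerns the methoxyphenyl group and is within the scatter. For the measured compounds named here, the step to compound 3 thus has no precedent here, and the expectation rests on compound 1 alone: a change of a 1.0-fold lower number from compound 1 to compound 3 (0.00 log units; within the scatter) is expected, with wide uncertainty. Compound 3 is estimated at 20000 nM, ranging from 5000 nM to 80000 nM.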

Compound 3, half-maximal inhibitory concentration in the vitamin D3 receptor assay: > 80000 nM
Compound 3: only a limit was reported (the forecaster's own chance of this, stated with the estimate: 25%); middle value at least 4.0-fold (0.60 log units) away from the limit.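

Within the data shown here, in the vitamin D3 receptor assay, the change from methoxycarbonyl to carboxy gives the first step beyond the scatter, an at least 3.9-fold higher number from compound 1 to compound 3 (0.59 log units; beyond the scatter), and it shows that this position, on an oxygen next to a carbonyl group, is not indifferent to hydrogen in place of methyl. In the same assay compound 3 gives > 80000 nM, which is a limit and not a number. In a physicochemical assay for solubility, tested at 500 uM (on this read-out higher numbers stand for higher solubility and lower numbers for lower solubility), compound 1 gives 185000 nM and compound 3 gives 402000 nM. In the physicochemical assay the same change moves the read-out the other way in terms of benefit, with higher solubility for the acid: the measured solubility of compound 1, 185000 nM, and of compound 3, 402000 nM, a 2.2-fold higher number (0.34 log units; beyond the scatter).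

Going by these compounds, how far compound 3 lies past its limit stays open, as does the effect of the 3-methoxyphenyl group of compound 2 when paired with carboxy. Also open, on these data alone, is how an ethoxycarbonyl group or a primary amide in place of methoxycarbonyl would read in the vitamin D3 receptor assay, and whether either would also shift solubility.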